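Tail aryl replacement in the quinazoline-free benzylamine series

A few compounds are considered here, and "the series" means these few. Any claim that something is new, unique, unknown or untested is made for them only; others in the source may bear on it.

Three compounds share a core and differ only in the group on the benzylamine ring. In an assay on a protein complex for inhibition of ubiquitin carboxyl-terminal hydrolase 1/WD repeat-containing protein 48 (Homo sapiens), read by fluorescence (on this read-out lower numbers stand for stronger inhibition and higher numbers for weaker inhibition), compound 1 `FC(F)(F)c1ccccc1-c1nc(NCc2ccc(Cl)cc2)c2ccccc2n1` gives 4800 nM, compound 2 `FC(F)(F)c1ccccc1-c1nc(NCc2ccc(-c3ccccc3)cc2)c2ccccc2n1` gives 3700 nM, and compound 3 `FC(F)(F)c1ccccc1-c1nc(NCc2ccc(-c3ccc(Cl)c(Cl)c3)cc2)c2ccccc2n1` gives 2200 nM. Among the measured compounds shown here, compound 3 has the lowest number of the three, but only the step of a 2.2-fold lower number from compound 1 to compound 3 (0.34 log units; beyond the scatter) is beyond the scatter; the step of a 1.7-fold lower number from compound 2 to compound 3 (0.23 log units; within the scatter) is not. Compound 4 `FC(F)(F)c1ccccc1-c1nc(NCc2ccc(-c3cncnc3)cc2)c2ccccc2n1` carries the change (pyrimidin-5-yl in place of 3,4-dichlorophenyl on an aromatic carbon). For the measured compounds named here, the steps that bear on it, a 1.3-fold lower number from compound 1 to compound 2 (0.11 log units; within the scatter) and a 1.7-fold lower number from compound 2 to compound 3 (0.23 log units; within the scatter), both stay within the scatter, and no measured step exchanges a carbon-only ring for a ring with hetero atoms, so the data give no direct guide for this exchange. The expectation is a small move toward a higher number, not beyond the scatter, with wide uncertainty. Compound 4 is estimated at 4000 nM, in a range from 1500 nM to 10000 nM. The estimated step is a 1.8-fold higher number from compound 3 to compound 4 (0.26 log units; within the scatter).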

Compound 4, half-maximal inhibitory concentration: 3000 nM
Estimate against measurement, compound 4: 1.3-fold (0.12 log units) above; low and high end bracket the measured number.
By their numbers in this assay, from the lowest: compounds 3, 4, 2 and 1 (each within the scatter of the next, the first and the last beyond it).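

In this assay, among the compounds shown here, the first exchange of a ring of carbon only for a six-membered aromatic ring with hetero atoms at this place, para to a large group, leaves the number within the scatter of both carbon-only rings (a 1.4-fold higher number from compound 3 to compound 4 (0.13 log units; within the scatter); a 1.2-fold lower number from compound 2 to compound 4 (0.09 log units; within the scatter)). The same holds against the chloro group (a 1.6-fold lower number from compound 1 to compound 4 (0.20 log units; within the scatter)), so at this place the read-out separates pyrimidin-5-yl from none of the other three groups. Nothing measured on these compounds offers a reason for this result.

Going by these compounds, whether a carboxylic acid or a saturated amine such as morpholine at this place would take the number beyond the scatter stays open. So does the effect of hetero atoms placed elsewhere in this ring, as in pyridin-3-yl.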